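The source may hold more compounds than are shown below. What is called first, only, known or untested is meant among the compounds shown, and "the series" means these compounds.

Compound 1: `CC(C)N(Cc1cccc(OCCCCCC(=O)O)c1)C(=O)c1ccc(-c2cccc(N(C)C)c2)cc1` — > 26000 nM
Compound 2: `CC(C)N(Cc1cccc(OCCCCCC(=O)O)c1)C(=O)c1ccc(-c2ccc(Cl)c(Cl)c2)cc1` — > 26000 nM

In an ADME assay on Raji cells (Homo sapiens) for cytotoxicity, read by CellTiter-Glo and resazurin assay, with a stated time of 72 h (on this read-out higher numbers stand for an effect only at larger amounts of compound and lower numbers for an effect already at smaller amounts), compound 1 gives > 26000 nM, which is a limit of the assay rather than a measured number. In this assay compound 2 gives > 26000 nM, again a limit and not a number. Because both readings sit at the limit of > 26000 nM in this assay, at which 2 of the 2 values shown sit, the step that the two limits leave unreadable from compound 1 to compound 2 cannot be read, so the change from 3-(dimethylamino)phenyl to 3,4-dichlorophenyl tells nothing about size or direction. Compound 2 therefore stands only at the limit, with no number of its own.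

Compound 3 is `CC(C)N(Cc1cccc(OCCCCCC(=O)O)c1)C(=O)c1ccc(-c2cccc(Cl)c2)cc1`. It differs from compound 2 by hydrogen in place of chloro on an aromatic carbon; the same difference, cut one bond further out, reads 3,4-dichlorophenyl to 3-chlorophenyl. Among the compounds with values here, the only measured step that bears on it is the unreadable one from compound 1 to compound 2, so no step size can be taken from the data. The expected step that the limit leaves unreadable from compound 2 to compound 3 is therefore none beyond the scatter, with compound 3 most likely again at the limit. Compound 3 is estimated at 30000 nM, expected to lie between 13000 nM and 80000 nM.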

Compound 3, half-maximal effective concentration: > 21900 nM
Compound 3 gave a limit, no number (the forecaster's own chance of this, stated with the estimate: 80%); the middle value is on the limit's open side.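

In this assay compound 3 gives > 21900 nM, a limit of the assay and not a number. Within the data shown here, compound 1, compound 2 and compound 3 all stand at limits, and no step between them can be read. The compounds shown leave open whether 3-(dimethylamino)phenyl, 3,4-dichlorophenyl and 3-chlorophenyl differ at all in their effect on these cells.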